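A new side chain on the sulfur of compound 3

The compounds below may be only part of what the source reports. "The series", "measured", "known", "first", "only" and "open" are said of these compounds alone.

Measured so far in a functional assay on MV4-11 cells (Homo sapiens) for inhibition, read by resazurin assay, with a stated time of 72 h (on this read-out higher numbers stand for weaker inhibition of growth and lower numbers for stronger inhibition of growth), are these two compounds:
compound 1 `COCCOc1nc(C)c(-c2ccnc(Nc3ccc(OC)cc3OC)n2)s1` gives 1980 nM
compound 2 `COc1ccc(Nc2nccc(-c3sc(SCc4cccnc4)nc3C)n2)c(OC)c1` gives 270 nM

Of these two, compound 2 has the lower number at 270 nM and so the stronger inhibition of growth. Compound 3 `COc1ccc(Nc2nccc(-c3sc(SCCCN(C)C)nc3C)n2)c(OC)c1` has not been measured yet. It differs from compound 2 by a single change 2-(dimethylamino)ethyl in place of pyridin-3-yl on a saturated chain carbon bound to a sulfur that puts 2-(dimethylamino)ethyl in place of pyridin-3-yl on a saturated chain carbon bound to a sulfur. Going by the values given here, one measured step bears on this, a 7.3-fold lower number from compound 1 to compound 2 (0.87 log units; beyond the scatter) as ((pyridin-3-yl)methyl)sulfanyl came in place of 2-methoxyethoxy on an aromatic carbon. Among the compounds with values here, that swap moved the number beyond the usual scatter, so a change in this side group can matter, yet no measured compound carries the new chain. In this assay the best guess is therefore no step beyond the scatter, with the direction left open and a larger step not ruled out. The expected 1.1-fold higher number from compound 2 to compound 3 (0.05 log units; within the scatter) is small on this estimate. Compound 3 is expected at 300 nM with 90 nM to 1000 nM as its estimated range.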

Compound 3, concentration for 50% growth inhibition: 370 nM
The estimate for compound 3 lay 1.2-fold (0.09 log units) below the measured number; low and high end bracket the measured number.
By their numbers in this assay, from the lowest: compounds 2 and 3 (each within the scatter of the next); then compound 1.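

The ring is not needed at this position to hold the number in this assay. Replacing pyridin-3-yl on the saturated chain carbon bound to a sulfur with 2-(dimethylamino)ethyl, which has no ring, gives a 1.4-fold higher number from compound 2 to compound 3 (0.14 log units; within the scatter), so an aromatic and an open-chain group here cannot be told apart. The second sulfur-linked side chain also shows a 5.4-fold lower number from compound 1 to compound 3 (0.73 log units; beyond the scatter), which means the gain over the 2-methoxyethoxy group of compound 1 is now seen with two different groups rather than one, while nothing shown here explains it.

Both sulfur-linked side chains contain a nitrogen, and both differ from compound 1 in the linking atom as well as in the rest of the chain, so the compounds shown do not separate the contribution of the sulfur from that of the nitrogen. A plain propyl chain on the sulfur, a (3-(dimethylamino)propyl)oxy group on the aromatic carbon, or a carboxylic acid at the chain end would each address part of that question, and a longer chain would test how far the amine can sit from the sulfur.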